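Triazole for Thiazole on the Aryl Ring

The source may report more compounds than this note shows. Statements on the series, on what has been measured and on what is new or still open speak of the compounds shown alone.

Measured so far:
compound 1 `c1ccc(-c2ccc(CCc3nc(CC4CCCC4)c[nH]3)cc2)nc1` — 425 nM
compound 2 `CCC(C)(C)Cc1c[nH]c(CCc2ccc(-c3cnsc3)cc2)n1` — 44 nM
compound 3 `O=C(O)c1cc(F)c(F)cc1-c1ccc(CCc2nc(CC3CCCCC3)c[nH]2)cc1` — 63 nM

All three numbers come from a functional assay on HEK293 cells for agonist activity at Bombesin receptor subtype-3 (Homo sapiens), read by luminescence and calcium flux, with a stated time of 10 min; a lower number here means that less compound is needed, a higher number that more compound is needed for the effect. Compound 2 holds the lowest of the three, but compound 3 sits within the scatter of it, so the two cannot be told apart; only compound 1 stands clearly higher, and that gap is beyond the scatter. Among the compounds with values here, no single-change pair among the measured compounds exists, so no step size has been measured yet.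

Compound 4 `CCC(C)(C)Cc1c[nH]c(CCc2ccc(-n3cncn3)cc2)n1` is the next entry. It is built from compound 2 by one change: 1H-1,2,4-triazol-1-yl in place of 1,2-thiazol-4-yl on an aromatic carbon. The group that leaves and the group that enters are both small five-membered aromatic rings of the same heavy-atom count, so the shape of the molecule changes little, while the count of hetero atoms and acceptors rises.

Within the data shown here, with no measured step to lean on, the step from compound 2 to compound 4 is expected to be a modest loss, a 2.7-fold higher number from compound 2 to compound 4 (0.44 log units; beyond the scatter), possibly at the edge of the scatter rather than far beyond it. Compound 4 is therefore estimated at 120 nM, with a range of 40 nM to 400 nM, in this assay, pending the measurement.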

Compound 4, half-maximal effective concentration: 570 nM
Compound 4: middle estimate off by 4.8-fold (0.68 log units), on the low side; measured number outside the range, above it.
By their numbers in this assay, from the lowest: compounds 2 and 3 (each within the scatter of the next); then compounds 1 and 4 (each within the scatter of the next).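

In this assay, 1H-1,2,4-triazol-1-yl in place of 1,2-thiazol-4-yl, on an aromatic carbon para to a large group, gives a 13-fold higher number from compound 2 to compound 4 (1.11 log units; beyond the scatter), the first step measured within the series, and a large one. Within the data shown here, the position therefore distinguishes between two five-membered aromatic rings that have the same heavy-atom count, carry no net charge and have no hydrogen-bond donors, which the earlier compounds could not show, as they differ from one another in more than one place. No measurement shown bears on why the step is this large.

Among these compounds, the single pair does not separate the effect of the different ring hetero atoms from that of attaching the ring through nitrogen rather than carbon, and a pyrazol-4-yl or imidazol-1-yl ring at this position would help to pull those two apart. As far as these compounds go, it also remains open whether a step of this size would hold with the other side chains on the core, as carried by compound 1 and compound 3.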